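The compounds below may be only part of what the source reports. "The series", "measured", "known", "first", "only" and "open" are said of these compounds alone.

In a functional assay on MCF7 cells (Homo sapiens) for antiproliferative activity, read by MTT assay, with a stated time of 24 h, tested at 12.5 uM (on this read-out lower numbers stand for a stronger effect and higher numbers for a weaker effect at the one concentration tested), compound 1 `OC(CCn1nc2c(Br)c(Br)c(Br)c(Br)c2n1)c1ccc(F)cc1` gives 116%, and compound 2 `COc1cccc(C(O)CCn2nc3c(Br)c(Br)c(Br)c(Br)c3n2)c1` gives 121%. For the measured compounds named here, the only measured step, a number 5 percentage points higher from compound 1 to compound 2 (within the scatter), swaps one group on the aromatic ring for another. Going by the values given here, compound 2 stands highest of the two numbers so far, yet its gap to compound 1 lies within the scatter, so no order can be claimed. Compound 3 `OC(CCn1nc2c(Br)c(Br)c(Br)c(Br)c2n1)c1cccc(Cl)c1` differs from compound 2 in the following way: chloro in place of methoxy on an aromatic carbon. Among the compounds with values here, since the one comparable step was within the scatter, compound 3 is expected to show a number 3 percentage points lower from compound 2 to compound 3 (within the scatter), no shift beyond the scatter. Compound 3 is estimated at 118%, within 103% to 133%.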

Compound 3, a percentage reported as activity, at one concentration (the size of the read-out at that concentration, not a potency): 97%
Beside the measured number, compound 3's estimate is 21 percentage points above it; the whole stated range lies above it.
By their numbers in this assay, from the lowest: compound 3; then compounds 1 and 2 (each within the scatter of the next).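

Chloro in place of methoxy on this aromatic carbon gives a number 24 percentage points lower from compound 2 to compound 3 (beyond the scatter) in this assay; unlike the earlier step, this one shows that the group here can shift the read-out beyond the scatter. The 3-chlorophenyl group also differs from 4-fluorophenyl, with a number 19 percentage points lower from compound 1 to compound 3 (beyond the scatter) on that comparison, so compound 3 stands apart from the other two. Nothing measured here explains this shift. 

As far as these compounds go, whether the shift is specific to chloro remains open, as a bromo, a methyl or an amine on this same carbon could read differently. The compounds shown also leave open how a longer chain would read.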